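Thiophen-2-yl in Place of Phenyl on the Amide

The compounds below may be only part of what the source reports. "The series", "measured", "known", "first", "only" and "open" are said of these compounds alone.

Measured in a functional assay on A2780 cells (Homo sapiens) for antiproliferative activity, read by fluorescence, with a stated time of 72 h; a lower number here means a stronger inhibitor, a higher number a weaker inhibitor:
Compound 1 `CN1CCC(C(=O)N2Cc3c(NC(=O)Nc4cccc(F)c4)n[nH]c3C2(C)C)CC1` gives 350 nM.
Compound 2 `CN1CCC(C(=O)N2Cc3c(NC(=O)c4ccco4)n[nH]c3C2(C)C)CC1` gives only a limit of this assay, > 5000 nM.
Compound 3 `CN1CCC(C(=O)N2Cc3c(NC(=O)c4ccccc4)n[nH]c3C2(C)C)CC1` gives 160 nM.

Among the measured numbers, compound 3 stands lowest; its nearest neighbour is compound 1, with a 2.2-fold lower number from compound 1 to compound 3 (0.34 log units; beyond the scatter). Compound 2 is shown only as a limit, (the limit of > 5000 nM in this assay, at which 1 of the 3 values shown sits). Compound 4 `CN1CCC(C(=O)N2Cc3c(NC(=O)c4cccs4)n[nH]c3C2(C)C)CC1` differs from compound 3 in one place: thiophen-2-yl in place of phenyl on a carbonyl carbon. Among the compounds with values here, the step that bears most directly on this change is the one between compound 2 and compound 3, where a five-membered aromatic ring also stood against phenyl and an at least 31-fold lower number from compound 2 to compound 3 (1.49 log units; beyond the scatter) was found. That change was large, but furan-2-yl is not thiophen-2-yl, and no thiophene has been measured here, so the size of the coming step is uncertain. Compound 4 is therefore expected to sit above compound 3, with a 5.0-fold higher number from compound 3 to compound 4 (0.70 log units; beyond the scatter) as the estimated step, and the estimate for compound 4 is 800 nM, between 250 nM and 4000 nM.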

Compound 4, half-maximal inhibitory concentration: 30 nM
Compound 4: the middle estimate sits 27-fold (1.43 log units) above what was measured; the measured number lies below the stated range.
By their numbers in this assay, from the lowest: compound 4; then compound 3; then compound 1. At a limit, above all of these: compound 2.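

In this assay, a five-membered aromatic ring on this carbonyl carbon is not in itself a loss, as thiophen-2-yl in place of phenyl gives a 5.3-fold lower number from compound 3 to compound 4 (0.73 log units; beyond the scatter), the opposite direction to the change seen with furan-2-yl. The two five-membered rings are far from interchangeable at this position, with thiophen-2-yl in place of furan-2-yl giving an at least 160-fold lower number from compound 2 to compound 4 (2.22 log units; beyond the scatter), a step read against a limit held by compound 2: the limit of > 5000 nM in this assay, at which 1 of the 4 values shown sits. Thiophen-2-yl also improves on (3-fluorophenyl)amino on the same carbonyl carbon, with a 12-fold lower number from compound 1 to compound 4 (1.07 log units; beyond the scatter).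

From the compounds shown here alone, it remains open whether other five-membered rings, such as thiophen-3-yl or thiazol-2-yl, would follow compound 4 or compound 2. Going by these compounds, it is equally open whether a methyl group or a chlorine on the thiophene would keep the number of compound 4.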